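This account rests on a few compounds, and the source may have more. Where it says the series, first, only, none or still open, it means among the compounds named here.

Working notes on the series. Compound 1 `CC[C@H](CCn1cncn1)c1ccccc1` in an ADME assay on RD cells (Homo sapiens) for cytotoxicity, read by MTT assay, with a stated time of 3 days (a lower number here means that less compound is tolerated, a higher number that more compound is tolerated), gives 99.8 ug/mL. Compound 2 `CC[C@@H](CCn1cncn1)c1ccc(F)cc1` gives 91.6 ug/mL in this assay, and compound 3 `CC[C@@H](CCn1cncn1)c1ccc(Cl)cc1` gives 55.3 ug/mL. Compound 2 stands second highest of the three numbers; its nearest neighbour is compound 1 and its furthest is compound 3, and both of these gaps lie within the scatter. Going by the values given here, the only single-point step among the measured compounds, a 1.7-fold lower number from compound 2 to compound 3 (0.22 log units; within the scatter), likewise lies within the scatter.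

The unmeasured compound 4 `CC[C@@H](CCn1cncn1)c1ccc(C)cc1` differs from compound 2 by methyl in place of fluoro on an aromatic carbon. Among the compounds with values here, the one measured step that bears on this change is the exchange of the same substituent at the same aromatic carbon, a 1.7-fold lower number from compound 2 to compound 3 (0.22 log units; within the scatter), which did not move the number beyond the scatter. Within the data shown here, with only that step to go on, and it being a small one, no step beyond the scatter is expected in this assay from compound 2 to compound 4 in either direction, with the range kept wide because a single comparison carries little weight. The estimate for compound 4 in this assay is 75 ug/mL, with a range from 40 ug/mL to 140 ug/mL. This estimate corresponds to an expected step of a 1.2-fold lower number from compound 2 to compound 4 (0.09 log units; within the scatter).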

Compound 4, half-maximal cytotoxic concentration: 79.4 ug/mL
The estimate for compound 4 lay 1.1-fold (0.02 log units) below the measured number; the range from low to high includes it.
By their numbers in this assay, from the lowest: compounds 3, 4, 2 and 1 (each within the scatter of the next).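

In this assay the aromatic carbon para to a large group has now been read with a carbon substituent as well as two halogens, and the exchange of fluoro for methyl, a 1.2-fold lower number from compound 2 to compound 4 (0.06 log units; within the scatter), lies within the scatter. Going by these compounds alone, the exchange of chloro for methyl, a 1.4-fold higher number from compound 3 to compound 4 (0.16 log units; within the scatter), also lies within the scatter, and it is the first step at this position that does not start from the fluoro compound. Every step printed among fluoro, chloro and methyl at this carbon is thus within the scatter, so these three groups cannot be told apart here, and no order among them can be drawn from this assay.

Nothing on hand gives a reason for these numbers, and the absence of a step beyond the scatter remains without an explanation. Open, from the compounds shown here alone, is whether an amine, a carboxylic acid, a methoxy group or a trifluoromethyl group on this same carbon, or a longer chain in place of the methyl, would give a step beyond the scatter in this assay on the shared core.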